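From ethoxycarbonyl to methoxycarbonyl: an exposure estimate

The source may hold more compounds than are shown below. What is called first, only, known or untested is meant among the compounds shown, and "the series" means these compounds.

Within the data shown here, in an ADME assay on the whole organism (Rattus norvegicus, strain Sprague-Dawley) for pharmacokinetics, read by LC-MS, with a stated time of 48 h, at a dose of 10 mg/kg by the oral route (on this read-out lower numbers stand for lower exposure and higher numbers for higher exposure at the dose given), compound 1 `CC#CCn1c(N2CCC[C@@H](N)C2)nc2c1c(=O)n(Cc1ccc(Cl)cc1C(=O)O)c(=O)n2C` gives 1300 ng.h/mL, while compound 2 `CC#CCn1c(N2CCC[C@@H](N)C2)nc2c1c(=O)n(Cc1ccc(Cl)cc1C(=O)OCC)c(=O)n2C` gives 4540 ng.h/mL, the higher of the two numbers measured so far. The next structure, compound 3 `CC#CCn1c(N2CCC[C@@H](N)C2)nc2c1c(=O)n(Cc1ccc(Cl)cc1C(=O)OC)c(=O)n2C`, differs from compound 2 in one place: hydrogen in place of methyl on a saturated chain carbon bound to an oxygen next to a carbonyl group. Put in words, hydrogen stands in place of methyl on a saturated chain carbon bound to an oxygen next to a carbonyl group, so ethoxycarbonyl becomes methoxycarbonyl.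

Among the measured compounds shown here, the one measured step that bears on this is a 3.5-fold higher number from compound 1 to compound 2 (0.54 log units; beyond the scatter), modest but beyond the scatter, with ethyl in place of hydrogen on an oxygen next to a carbonyl group. Compound 3 keeps a carbon group on that oxygen, so it is expected to stay closer to compound 2 at 4540 ng.h/mL than to compound 1. For the measured compounds named here, no measurement yet compares methyl with ethyl at this place, so only a slight fall, within the scatter of this assay, is expected. The estimated change is a 1.3-fold lower number from compound 2 to compound 3 (0.11 log units; within the scatter). For compound 3 the expected value is 3500 ng.h/mL, with an estimated range of 1600 ng.h/mL to 7500 ng.h/mL.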

Compound 3, area under the concentration-time curve: 6110 ng.h/mL
Beside the measured number, compound 3's estimate is 1.7-fold (0.24 log units) below it; the measured number falls inside the stated range.
By their numbers in this assay, from the lowest: compound 1; then compounds 2 and 3 (each within the scatter of the next).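

In this assay, going from ethoxycarbonyl to methoxycarbonyl gives a 1.3-fold higher number from compound 2 to compound 3 (0.13 log units; within the scatter), so on these numbers the ethyl and methyl groups on this oxygen cannot be told apart. Putting methyl in place of the hydrogen of the carboxylic acid gives a 4.7-fold higher number from compound 1 to compound 3 (0.67 log units; beyond the scatter), a step beyond the scatter that now stands alongside the one already seen for ethyl, so across these three compounds the clear difference lies between the free carboxylic acid and either carbon group, not between the two carbon groups. Nothing available explains why a carbon group on this oxygen goes with a different exposure, and these numbers alone cannot supply a reason.

As far as these compounds go, what remains open is how far this tolerance extends: a longer chain such as propyl, a branched group such as isopropyl, or a ring such as phenyl on the same oxygen could either stay level with compound 2 and compound 3 or part from them. From the compounds shown here alone, it is also open whether an amide in place of this oxygen link would keep the exposure seen with the two carbon groups.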